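Amine substituent series: cyclopropyl to 4-fluorobenzyl

A few compounds are considered here, and "the series" means these few. Any claim that something is new, unique, unknown or untested is made for them only; others in the source may bear on it.

Within the data shown here, compound 3 `COc1cc(Oc2cccc(Nc3ccccc3)c2)cc(OC)c1CNC1CC1` gives 12300 nM in a functional assay on HT-29 cells (Homo sapiens) for inhibition, read by MTT assay, with a stated time of 72 h (on this read-out higher numbers stand for weaker inhibition and lower numbers for stronger inhibition), the highest of the three numbers so far. Compound 1 `COc1ccc(CCCNCc2c(OC)cc(Oc3ccc(Nc4ccccc4)cc3)cc2OC)cc1` gives 6890 nM in this assay, within the scatter of compound 3. Among the measured compounds shown here, compound 2 `COc1cc(Oc2cccc(Nc3ccccc3)c2)cc(OC)c1CNCc1ccc(Br)cc1` gives 3060 nM in this assay; the step of a 4.0-fold higher number from compound 2 to compound 3 (0.60 log units; beyond the scatter) is the only single-change comparison and bears directly on the next step, since compound 4 `COc1cc(Oc2cccc(Nc3ccccc3)c2)cc(OC)c1CNCc1ccc(F)cc1` differs from compound 3 by 4-fluorobenzyl in place of cyclopropyl on an amine nitrogen. A 4-fluorobenzyl on the amine nitrogen resembles the 4-bromobenzyl of compound 2 more than the cyclopropyl of compound 3, so a lower number, roughly that step reversed, is expected in this assay. Compound 4 is estimated at 3500 nM, range 1500 nM to 8000 nM, an expected step of a 3.5-fold lower number from compound 3 to compound 4 (0.55 log units; beyond the scatter).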

Compound 4, half-maximal inhibitory concentration: 2750 nM
Estimate against measurement, compound 4: 1.3-fold (0.10 log units) above; the measured number falls inside the stated range.
By their numbers in this assay, from the lowest: compounds 4 and 2 (each within the scatter of the next); then compounds 1 and 3 (each within the scatter of the next).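

On the amine nitrogen, 4-fluorobenzyl in place of cyclopropyl gives a 4.5-fold lower number from compound 3 to compound 4 (0.65 log units; beyond the scatter) in this assay and so adds a second halogen-bearing benzyl to the comparison with cyclopropyl. Fluoro in place of bromo on an aromatic carbon gives a 1.1-fold lower number from compound 2 to compound 4 (0.05 log units; within the scatter), so these two halogens are not separated on this read-out. No measured evidence here accounts for either step.

From the compounds shown here alone, whether an unsubstituted benzyl or a 4-methoxybenzyl on the amine nitrogen would hold this level remains open. Also open, going by these compounds, is whether a non-aromatic group such as cyclohexylmethyl would do the same.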